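The source may report more compounds than this note shows. Statements on the series, on what has been measured and on what is new or still open speak of the compounds shown alone.

Measured so far:
- compound 1 `Cc1ccc(CN2CCC=C(CCC(=O)NO)C2=O)cc1`: 5000 nM
- compound 2 `Cc1ccccc1CN1CCC=C(CCC(=O)NO)C1=O`: > 10000 nM (a limit of the assay, not a number)

Within the data shown here, in a functional assay on ACHN cells (Homo sapiens) for inhibition, read by sulforhodamine B assay (on this read-out lower numbers stand for stronger inhibition of growth and higher numbers for weaker inhibition of growth), compound 1 gives 5000 nM, the only true number so far. It therefore serves as the sole reference point, and no ranking can be drawn from it. The other result is the limit of > 10000 nM in this assay, at which 1 of the 2 values shown sits.

Next is compound 3 `O=C(CCC1=CCCN(Cc2ccc([N+](=O)[O-])cc2)C1=O)NO`, which keeps the core of compound 1 and differs by one group: nitro in place of methyl on an aromatic carbon. The change is nitro in place of methyl on an aromatic carbon, para to a large group.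

Among the measured compounds shown here, only one measured step bears on this, and only loosely: an at least 2.0-fold higher number from compound 1 to compound 2 (0.30 log units; that floor lies within the scatter). That step puts 2-methylphenyl in place of 4-methylphenyl, so it tells nothing directly about replacing the methyl with nitro. For the measured compounds named here, with no measured precedent for this exchange, no step beyond the scatter is expected in this assay, and no direction can be favoured. The expected change is no change at the digits printed from compound 1 to compound 3 (within the scatter).

For compound 3 the estimated value is 5000 nM, with an expected range from 2000 nM to 12000 nM.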

Compound 3, concentration for 50% growth inhibition: 5210 nM
Compound 3: middle estimate off by 1.0-fold (0.02 log units), on the low side, within the range that was stated.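

Working notes on this position, in this assay: at the aromatic carbon para to a large group, nitro in place of methyl gives a 1.0-fold higher number from compound 1 to compound 3 (0.02 log units; within the scatter), so this position takes 3 heavy atoms for 1 and 2 hydrogen-bond acceptors for 0 with no step beyond the scatter. Among these compounds, compound 1 and compound 3 are the first pair with two true numbers, which makes this the first exchange that can be read as a measured size rather than against a limit of the assay, and it holds for this one pair only. No measurement shown bears on why the number stays in place.

Compound 2, the 2-methylphenyl compound, remains a limit of the assay and not a number: the limit of > 10000 nM in this assay, at which 1 of the 3 values shown sits.
On these data alone, whether an amine or a carboxylic acid on the same aromatic carbon would also leave the number in place stays open, as does whether nitro would track methyl if it stood where the methyl of compound 2 stands.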